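Propylamino in place of methylamino on the core of compound 1

This account rests on a few compounds, and the source may have more. Where it says the series, first, only, none or still open, it means among the compounds named here.

Going by the values given here, compound 1 `CNc1nc(NCc2ccc(C(=O)Nc3ccc(F)cc3)cc2)c2ccccc2n1` has the highest of the three numbers measured so far: in a functional assay on HCT-116 cells (Homo sapiens) for inhibition, read by luminescence and resazurin assay, with a stated time of 3 days (on this read-out lower numbers stand for stronger inhibition and higher numbers for weaker inhibition), compound 1 gives 2900 nM. Among the compounds with values here, its nearest neighbour is compound 2 `CNc1nc(NCc2ccc(NC(=O)c3ccc(F)cc3)cc2)c2ccccc2n1`, which in this assay gives 1600 nM; the step of a 1.8-fold lower number from compound 1 to compound 2 (0.26 log units; within the scatter) is the only single-place step among the measured compounds. Compound 3 `Cc1ccc2nc(N(C)C)nc(NCc3ccc(C(=O)NC4CCN(Cc5ccc(F)cc5)CC4)cc3)c2c1` differs from compound 1 in several places at once; in this assay compound 3 gives 800 nM, a lower number than compound 1 and the furthest of the three from it.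

Compound 4 `CCCNc1nc(NCc2ccc(C(=O)Nc3ccc(F)cc3)cc2)c2ccccc2n1` is compound 1 with ethyl in place of hydrogen on a saturated chain carbon bound to a nitrogen on an aromatic ring; read one bond further out, this is methyl to propyl, methylamino to propylamino. Within the data shown here, no measured step touches this position: the step of a 1.8-fold lower number from compound 1 to compound 2 (0.26 log units; within the scatter) concerns the amide in the side chain, and compound 3 carries dimethylamino together with other changes, so its value cannot be set against compound 1 for this change alone. With nothing bearing on it directly, the working expectation for compound 4 in this assay is a step of a 1.2-fold lower number from compound 1 to compound 4 (0.06 log units; within the scatter), not beyond the scatter. Compound 4 is therefore estimated at 2500 nM, with a range from 900 nM to 7000 nM.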

Compound 4, half-maximal inhibitory concentration: 1500 nM
Compound 4: middle estimate off by 1.7-fold (0.22 log units), on the high side; low and high end bracket the measured number.
By their numbers in this assay, from the lowest: compounds 3, 4, 2 and 1 (each within the scatter of the next, the first and the last beyond it).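

The position on the core of compound 1 now has a reading of its own: in this assay, propylamino in place of methylamino gives a 1.9-fold lower number from compound 1 to compound 4 (0.29 log units; within the scatter), so this read-out does not separate the two compounds. Ethyl on this saturated chain carbon, 2 heavy atoms with no ring and no hydrogen-bond donors or acceptors, therefore leaves the number within the scatter, as does the amide exchange in the side chain, a 1.8-fold lower number from compound 1 to compound 2 (0.26 log units; within the scatter), so neither single-place step from compound 1 yet moves the number beyond the scatter. No evidence on hand accounts for this step.

Going by these compounds, a single pair at this position gives no trend with chain length, and it remains open whether a longer chain such as butylamino, or a chain ending in an amine or a carboxylic acid, would also stay within the scatter of compound 1. On these data alone, it is equally open whether propylamino in place of methylamino would read the same on compound 2, which carries the other amide orientation in the side chain.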